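Changing the Group on the Carbonyl of Compound 2

The source may report more compounds than this note shows. Statements on the series, on what has been measured and on what is new or still open speak of the compounds shown alone.

Solubility tells how much of a compound stays dissolved, and it often decides how easily a compound can be tested further. Compound 2 `O=C(c1ccnc(Nc2nc3cnc(Nc4ccc(F)c(F)c4)cc3[nH]2)c1)N1CCN(C2CC2)CC1` stands at < 5000 nM in a physicochemical assay for solubility, read by HPLC, using the shake flask method, in phosphate buffer, measured as kinetic solubility, with a stated time of 20 h, at pH 6.5 (a higher number here means a more soluble compound, a lower number a less soluble compound), and this is a limit of the assay, not a number. Compound 3 `C[C@@H]1CN(C(=O)c2ccnc(Nc3nc4cnc(Nc5ccc(F)c(F)c5)cc4[nH]3)c2)C[C@H](C)N1` differs from compound 2 in one place, on a carbonyl carbon, where 3,5-dimethylpiperazin-1-yl stands in place of 4-cyclopropylpiperazin-1-yl: 3,5-dimethylpiperazin-1-yl in place of 4-cyclopropylpiperazin-1-yl on a carbonyl carbon and the rest of the structure stays the same.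

Compound 1 `C[C@@H]1CN(C(=O)c2ccnc(Nc3nc4cnc(Nc5cccc(C(F)(F)F)c5)cc4[nH]3)c2)C[C@H](C)N1` also holds the 3,5-dimethylpiperazin-1-yl group and gives 200000 nM as a true number in this assay and this single value is what the expectation for compound 3 rests on. The expected step is an at least 16-fold higher number from compound 2 to compound 3 (1.20 log units; beyond the scatter) and it should point towards higher solubility, beyond the usual scatter. Going by the values given here, with only one such compound to go on, the range has to stay wide. Compound 3 is estimated at 80000 nM with an expected range from 10000 nM to 250000 nM in this assay once it is measured.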

Compound 3, solubility: 100000 nM
Compound 3: middle estimate off by 1.3-fold (0.10 log units), on the low side; the range from low to high includes it.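

In this assay, going by these compounds alone, 3,5-dimethylpiperazin-1-yl in place of 4-cyclopropylpiperazin-1-yl on a carbonyl carbon gives an at least 20-fold higher number from compound 2 to compound 3 (1.30 log units; beyond the scatter), so this change can now be read on its own with the 3,4-difluorophenyl group held fixed, which the earlier compounds did not allow. A second comparison keeps 3,5-dimethylpiperazin-1-yl fixed and has 3,4-difluorophenyl in place of 3-(trifluoromethyl)phenyl on a nitrogen on an aromatic ring; it gives a 2.0-fold lower number from compound 1 to compound 3 (0.30 log units; within the scatter), so no real difference between these two groups can be read here. The first step has only a lower bound because compound 2 carries a limit of the assay and not a number: the limit of < 5000 nM in this assay, at which 1 of the 3 values shown sits.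

The compounds shown do not tell whether the large step goes with the hydrogen-bond donor that enters, the two methyl groups with their defined stereocentres, or the cyclopropyl ring that leaves. A plain piperazin-1-yl, a 4-methylpiperazin-1-yl or a morpholin-4-yl group on the same carbonyl carbon would help to pull these parts apart.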